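A Bromo for Chloro Swap With Little Room to Move

This account rests on a few compounds, and the source may have more. Where it says the series, first, only, none or still open, it means among the compounds named here.

In a functional assay on NCI-H460 cells (Homo sapiens) for inhibition, read by MTT assay, with a stated time of 24 h, tested at 1 ug/mL (on this read-out higher numbers stand for more inhibition of growth at the one concentration tested and lower numbers for less inhibition of growth), compound 1 (`O=C(CCCCC1CCSS1)Nc1ccc(OC(F)(F)F)cc1`) gives 12.2% while compound 2 (`O=C(CCCCC1CCSS1)Nc1ccccn1`) gives 0.81% and compound 3 (`O=C(CCCCC1CCSS1)Nc1ccc(Cl)cn1`) gives 6.26% and so stands within the scatter of both others. Compound 4 (`O=C(CCCCC1CCSS1)Nc1ccc(Br)cn1`) is still unmeasured and carries bromo in place of chloro on an aromatic carbon. For the measured compounds named here, no measured pair compares these two halogens directly. Going by the values given here, the one measured step that bears on the change, a number 5.5 percentage points higher from compound 2 to compound 3 (within the scatter) for chloro in place of hydrogen on an aromatic carbon, lies within the scatter, so no shift beyond the scatter is expected in this assay here. The expected step of a number 0.7 percentage points higher from compound 3 to compound 4 (within the scatter) stays within the scatter in either direction. Compound 4 is estimated at 7% (expected range 1% to 16%).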

Compound 4, percent growth inhibition at one concentration: 13.1%
Beside the measured number, compound 4's estimate is 6.1 percentage points below it; the measured number falls inside the stated range.
By their numbers in this assay, from the lowest: compounds 2, 3, 1 and 4 (each within the scatter of the next, the first and the last beyond it).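

At this position, on an aromatic carbon para to a large group, swapping one halogen for the other does not clear the scatter in this assay (a number 6.8 percentage points higher from compound 3 to compound 4 (within the scatter)). Measured against hydrogen, however, bromo gives a modest step beyond the scatter (a number 12.3 percentage points higher from compound 2 to compound 4 (beyond the scatter)), which chloro did not give (a number 5.5 percentage points higher from compound 2 to compound 3 (within the scatter)). Nothing available here accounts for this result.

From the compounds shown here alone, what an amine, a methoxy group or a nitrile would give in place of bromo remains open. So does whether the step from hydrogen to bromo would hold at other concentrations or in other cell lines.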